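Compound 4: a larger ring on the sulfonyl sulfur

The source may report more compounds than this note shows. Statements on the series, on what has been measured and on what is new or still open speak of the compounds shown alone.

Compound 1 `COC(=O)c1ccccc1-n1nc(C(F)(F)F)cc1C(=O)Nc1ccc(S(=O)(=O)N2CCCC2)cc1` gives "not determined" (no result reported) as its result
Compound 2 `O=C(O)c1ccccc1-n1nc(C(F)(F)F)cc1C(=O)Nc1ccc(S(=O)(=O)N2CCCC2)cc1` gives "not determined" (no result reported) as its result
Compound 3 `Cn1nc(C(F)(F)F)cc1C(=O)Nc1ccc(S(=O)(=O)N2CCCCC2)cc1` gives > 300000 nM as its result

In an ADME assay on Vero cells (Chlorocebus sabaeus) for cytotoxicity, read by MTT assay (a lower number here means that less compound is tolerated, a higher number that more compound is tolerated), only compound 3 has a reported result. For compound 3 the entry > 300000 nM is a limit, not a number. Going by the values given here, it is the only reading available, so no measured step is there to guide a prediction.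

Compound 4 `Cn1nc(C(F)(F)F)cc1C(=O)Nc1ccc(S(=O)(=O)N2CCCCCCC2)cc1` differs from compound 3 in one place, on a sulfonyl sulfur, with a group of 8 heavy atoms (7 carbon, 1 nitrogen; one eight-membered non-aromatic ring with 1 hetero atom) in place of a group of 6 heavy atoms (5 carbon, 1 nitrogen; one six-membered non-aromatic ring with 1 hetero atom), on a sulfonyl sulfur as the change. The piperidin-1-yl group leaves and a larger ring enters.

Among the compounds with values here, with no step to go on, a modest downward move in this assay is expected, or none beyond the scatter. The estimated change an at least 1.2-fold lower number from compound 3 to compound 4 (0.07 log units; that floor lies within the scatter) is therefore small. For compound 4 the estimated value is 250000 nM with an expected range from 80000 nM to 300000 nM and a fair chance of another limit.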

Compound 4, half-maximal cytotoxic concentration: 16000 nM
For compound 4 the middle estimate is 16-fold (1.19 log units) above the measured one; the whole stated range lies above it.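

In this assay, going by these compounds alone, exchanging the piperidin-1-yl group on the sulfonyl sulfur for the eight-membered ring gives an at least 18-fold lower number from compound 3 to compound 4 (1.27 log units; beyond the scatter), the first sign that the group at this place can change how much compound the cells tolerate. The true size of this drop remains unknown because the entry for compound 3 is a limit and not a number: the limit of > 300000 nM in this assay, at which 1 of the 4 values shown sits.

A single pair cannot show whether the number falls steadily as the ring grows. A seven-membered ring, a morpholine ring or an open diethylamino group on the sulfonyl sulfur could each help to settle this.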